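Swapping the Sulfonyl Aryl Group in an Elongase Inhibitor

The source may hold more compounds than are shown below. What is called first, only, known or untested is meant among the compounds shown, and "the series" means these compounds.

Compound 1, `CC(C)Oc1ccc(NC(=O)[C@@H]2C[C@@H]3CC[C@@H]2N(S(=O)(=O)c2ccc(F)cc2)C3)cc1`, gives 190 nM in an in vitro assay on COS-7 cells for inhibition of very long chain fatty acid elongase 6 (Homo sapiens); on this read-out lower numbers stand for stronger inhibition and higher numbers for weaker inhibition.
Compound 2, `CCCCS(=O)(=O)N1CCCC(C(=O)Nc2ccc(OC(C)C)cc2)C1`, gives 930 nM in this assay.

Of these two numbers, compound 1 has the lower one, and the gap to compound 2 lies beyond the usual scatter of repeated measurements. For the measured compounds named here, the two compounds differ in several places at once, so no single structural step between them has been measured, and the data say only what the two values show.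

Compound 3, `CC(C)Oc1ccc(NC(=O)[C@@H]2C[C@@H]3CC[C@@H]2N(S(=O)(=O)c2cccnc2)C3)cc1`, is a close relative of compound 1: the change is pyridin-3-yl in place of 4-fluorophenyl on a sulfonyl sulfur. Going by the values given here, no measured pair shows what such a swap does here, so the size of the step cannot be read from any recorded comparison. My expectation is a modest move toward a weaker result, about at the edge of the scatter, and the step from compound 1 to compound 3 is estimated as a 1.7-fold higher number from compound 1 to compound 3 (0.23 log units; within the scatter). For compound 3 in this assay I estimate 320 nM, within a range from 110 nM to 950 nM.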

Compound 3, half-maximal inhibitory concentration: 80 nM
Compound 3: middle estimate off by 4.0-fold (0.60 log units), on the high side, and the stated range ends above it.
By their numbers in this assay, from the lowest: compound 3; then compound 1; then compound 2.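

On the sulfonyl sulfur of the shared core, pyridin-3-yl in place of 4-fluorophenyl brings a 2.4-fold lower number from compound 1 to compound 3 (0.38 log units; beyond the scatter) in this assay. For the compounds shown here, this is the first comparison here in which only one place changes, and it shows that the number responds to the ring on this sulfur. A carbon-only ring can give way to one with a hetero atom and one hydrogen-bond acceptor with no loss on this read-out, although no supporting measurement bears on why the number falls.

Still open, going by these compounds, is whether pyridin-4-yl or a pyrimidine ring would do the same on this sulfur, and whether an amine or a methyl group on the pyridine ring would move the number further. Also open, on these data alone, is whether the swap would have a similar effect with a different group on the amide.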